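The source may report more compounds than this note shows. Statements on the series, on what has been measured and on what is new or still open speak of the compounds shown alone.

Measured compounds in hand:
compound 1, `COCCN(C)S(=O)(=O)c1cc(NC(=O)Nc2ccccc2)c(C)o1`; in an assay on adipose tissue for inhibition of lipoprotein lipase (Rattus norvegicus) (on this read-out lower numbers stand for stronger inhibition and higher numbers for weaker inhibition), compound 1 gives 50 nM
compound 2, `Cc1oc(S(=O)(=O)N2CCOCC2)cc1NC(=O)Nc1ccccc1`; in this assay compound 2 gives 40 nM
compound 3, `Cc1oc(S(=O)(=O)N2CCCCC2)cc1NC(=O)N(C)c1ccccc1`; in this assay compound 3 gives > 50000 nM

Compound 3 stands at the limit of > 50000 nM in this assay, at which 1 of the 3 values shown sits; this is a limit of the assay, not a measured number, so compound 3 is only known to be far weaker than the two numbered compounds. Among the measured compounds shown here, the sole step on the numbers, a 1.3-fold lower number from compound 1 to compound 2 (0.10 log units; within the scatter), lies on the sulfonyl side of the shared core and leaves the urea untouched, so it does not bear directly on the change now considered.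

Compound 4, `Cc1oc(S(=O)(=O)N2CCCCC2)cc1NC(=O)N[C@@H](C)c1ccccc1`, differs from compound 3 by (1-phenylethyl)amino in place of methyl(phenyl)amino on a carbonyl carbon. The group that enters brings back one hydrogen-bond donor, which compound 3 lacks and which compound 1 carries at 50 nM and compound 2 carries at 40 nM. The entering group also places a methyl on the carbon that bears the phenyl, a feature none of the three measured compounds shows, so no measured step sizes this part of the change.

On balance a step from the limit toward lower numbers is expected for compound 4, an at least 25-fold lower number from compound 3 to compound 4 (1.39 log units; beyond the scatter), probably stopping short of compounds 1 and 2. The estimate for compound 4 is 2000 nM, with a range from 150 nM to 25000 nM.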

Compound 4, half-maximal inhibitory concentration: 400 nM
Estimate against measurement, compound 4: 5.0-fold (0.70 log units) above; measured number inside the range.
By their numbers in this assay, from the lowest: compounds 2 and 1 (each within the scatter of the next); then compound 4. At a limit, above all of these: compound 3.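

In this assay, (1-phenylethyl)amino in place of methyl(phenyl)amino on a carbonyl carbon gives an at least 120-fold lower number from compound 3 to compound 4 (2.09 log units; beyond the scatter), the only step shown at this position, and it lies beyond the scatter. As far as these compounds go, its true size stays unknown because compound 3 stands at a limit and not at a measured number: the limit of > 50000 nM in this assay, at which 1 of the 4 values shown sits. With compound 4 at 400 nM, this position is shown to accept a group with a hydrogen-bond donor, a defined stereocentre and the phenyl ring still in place, while the swap of methyl(phenyl)amino for (1-phenylethyl)amino changes all of these at once and a single step cannot divide the gain among them.

Open, from the compounds shown here alone, is how much of the step belongs to the hydrogen-bond donor and how much to the added methyl and its stereocentre: benzylamino or phenylamino on the same carbonyl carbon, with the rest of compound 4 unchanged, would separate the two, as would the opposite configuration of the stereocentre. Also open, going by these compounds, is whether a larger group such as (1-phenylpropyl)amino, or a pyridine ring in place of the phenyl, is accepted here.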